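A few compounds are considered here, and "the series" means these few. Any claim that something is new, unique, unknown or untested is made for them only; others in the source may bear on it.

Measured compounds:
- Compound 1, `CNc1nc(N)nc2c1ncn2/C=C1/CC1(CO)CO`; in an ADME assay on Akata cells (Homo sapiens) for cytotoxicity, with a stated time of 7 days (on this read-out higher numbers stand for lower toxicity in this test and lower numbers for higher toxicity in this test), compound 1 gives > 24000 nM, which is a limit of the assay rather than a number.
- Compound 2, `C=CCOc1nc(N)nc2c1ncn2/C=C1/CC1(CO)CO`; in this assay compound 2 gives > 20000 nM, again a limit of the assay.

Within the data shown here, compound 1 therefore stands only at a limit, and the one other value shown is a limit as well, so no ranking between them can be read. The step that the two limits leave unreadable from compound 1 to compound 2 is unreadable for the same reason, as both the limit of > 20000 nM in this assay, at which 1 of the 2 values shown sits, and the limit of > 24000 nM in this assay, at which 1 of the 2 values shown sits, show.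

Compound 3, `CCOc1nc(N)nc2c1ncn2/C=C1/CC1(CO)CO`, differs from compound 1 as follows: ethoxy in place of methylamino on an aromatic carbon. Among the measured compounds shown here, the only measured step that bears on this change, from compound 1 to compound 2, also swaps the methylamino group for an alkoxy group, and it gave no readable size. There is thus no sign in the numbers that such a change moves cytotoxicity beyond the scatter, and no direction can be claimed.

Compound 3 is therefore expected to sit at or beyond the limit in this assay, with an estimated value of 30000 nM, between 10000 nM and 100000 nM, which means an expected step that the limit leaves unreadable from compound 1 to compound 3.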

Compound 3, half-maximal cytotoxic concentration: > 20000 nM
Compound 3 gave a limit, no number; the forecaster's own chance of this, stated with the estimate: 85%; the middle value does not contradict the limit.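

Compound 3 gives only a limit of the assay, as do compound 1 and compound 2, so no step among these three compounds can be read: the limit of > 20000 nM in this assay, at which 2 of the 3 values shown sit. The compounds shown leave open at what concentration any of them turns toxic in this assay, and whether methylamino, allyloxy and ethoxy differ there at all.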